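The source may hold more compounds than are shown below. What is called first, only, known or untested is meant among the compounds shown, and "the series" means these compounds.

Measured in a functional assay on MDA-MB-231 cells (Homo sapiens) for antiproliferative activity, read by sulforhodamine B assay, with a stated time of 48 h (on this read-out higher numbers stand for weaker inhibition and lower numbers for stronger inhibition), are three compounds:
Compound 1 `COc1cc(OC)c2sc(-c3ccc(N/C=C\C(=O)c4cc(OC)c(OC)c(OC)c4)cc3)nc2c1` gives 15800 nM 
Compound 2 `COc1ccc(C(=O)/C=C\Nc2ccc(-c3nc4cc(OC)c(OC)c(OC)c4s3)cc2)cc1[N+](=O)[O-]` gives 17100 nM 
Compound 3 `COc1ccc(C(=O)/C=C\Nc2ccc(-c3nc4cc(OC)c(OC)c(OC)c4s3)cc2)cc1F` gives 16500 nM 

Compound 3 lies within the usual scatter of both other compounds, so these three numbers cannot be told apart and it holds no rank of its own among them. The next compound to consider is compound 4 `COc1cc(C(=O)/C=C\Nc2ccc(-c3nc4cc(OC)c(OC)c(OC)c4s3)cc2)cc(OC)c1OC`, which has 3,4,5-trimethoxyphenyl in place of 3-fluoro-4-methoxyphenyl on a carbonyl carbon. The change is 3,4,5-trimethoxyphenyl in place of 3-fluoro-4-methoxyphenyl on a carbonyl carbon and nothing else differs.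

Going by the values given here, one measured step bears directly on this kind of swap. It is a 1.0-fold lower number from compound 2 to compound 3 (0.02 log units; within the scatter) for fluoro in place of nitro on an aromatic carbon, and it stays within the scatter. Compound 1 also holds a 3,4,5-trimethoxyphenyl on its carbonyl carbon and gives 15800 nM in this assay even though its core is not the same, a number within the scatter of compound 3. None of these compounds shows a difference beyond the scatter, so no change beyond it is expected in this assay here, and no direction can be favoured. The estimated step is a 1.0-fold lower number from compound 3 to compound 4 (0.01 log units; within the scatter) and it would be too small to read. For compound 4 the expected value is 16000 nM with an estimated range from 7500 nM to 32000 nM in this assay.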

Compound 4, half-maximal inhibitory concentration: 16500 nM
For compound 4 the middle estimate is 1.0-fold (0.01 log units) below the measured one; the measured number falls inside the stated range.
By their numbers in this assay, from the lowest: compounds 1, 3, 4 and 2 (each within the scatter of the next).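

In this assay the group on the carbonyl carbon grows from 3-fluoro-4-methoxyphenyl, with 9 heavy atoms and 1 hydrogen-bond acceptor, to 3,4,5-trimethoxyphenyl, with 12 heavy atoms and 3 hydrogen-bond acceptors, and the result is no change at the digits printed from compound 3 to compound 4 (within the scatter) in the read-out. Going by these compounds alone, the earlier step at this position exchanged only one substituent on the ring, whereas here the whole group differs, and the swap of 3,4,5-trimethoxyphenyl for 4-methoxy-3-nitrophenyl likewise gives a 1.0-fold lower number from compound 2 to compound 4 (0.02 log units; within the scatter), so all three groups tried at this position give numbers that cannot be told apart. Compound 4 also forms a matched pair with compound 1 through a change away from this position, methoxy in place of hydrogen on an aromatic carbon, which gives a 1.0-fold higher number from compound 1 to compound 4 (0.02 log units; within the scatter) and so adds a second place where a change leaves the number within the scatter.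

No supporting measurement is available to explain why these numbers stay together. Still open, on these data alone, is whether an amine, a carboxylic acid or a longer chain on this carbonyl carbon would move the number beyond the scatter.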